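Three Compounds at the Toxicity Limit, a Fourth Expected There

The source may report more compounds than this note shows. Statements on the series, on what has been measured and on what is new or still open speak of the compounds shown alone.

Compound 1 `CCCCCOc1nc(N)nc2c1ncn2/C=C1/CC1(CO)CO`: in an ADME assay on Akata cells (Homo sapiens) for cytotoxicity, with a stated time of 7 days (on this read-out lower numbers stand for higher toxicity in this test and higher numbers for lower toxicity in this test), compound 1 gives > 20000 nM, which is a limit of the assay, not a number.
Compound 2 `CN(C)c1nc(N)nc2c1ncn2/C=C1/CC1(CO)CO`: compound 2 gives > 24000 nM, again a limit.
Compound 3 `Nc1nc(SC2CCCC2)c2ncn(/C=C3/CC3(CO)CO)c2n1`: compound 3 gives > 20000 nM, also a limit.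

Compound 3 therefore stands at the limit of > 20000 nM in this assay, at which 2 of the 3 values shown sit, while the remaining value sits at the limit of > 24000 nM in this assay, at which 1 of the 3 values shown sits. The steps a step that the two limits leave unreadable from compound 1 to compound 2, a step that the two limits leave unreadable from compound 1 to compound 3 and a step that the two limits leave unreadable from compound 2 to compound 3 cannot be sized, as every value is a limit. Compound 4 `CC(C)Nc1nc(N)nc2c1ncn2/C=C1/CC1(CO)CO` differs from compound 3 by isopropylamino in place of cyclopentylsulfanyl on an aromatic carbon. The measured steps bear on this change only by showing that exchanging the group on that aromatic carbon left every value at a limit, so no step beyond the scatter is expected in this assay. The expected value for compound 4 is 25000 nM, between 12000 nM and 60000 nM. This estimate means an expected step that the limit leaves unreadable from compound 3 to compound 4.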

Compound 4, half-maximal cytotoxic concentration: > 24000 nM
Compound 4: no number, only a limit; the forecaster's own chance of this, stated with the estimate: 85%; the middle value is on the limit's open side.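

Among these compounds, compound 4 also gives only a limit, so no step between it and compound 1, compound 2 or compound 3 can be read in this assay. The compounds shown leave open whether any group on that aromatic carbon gives a readable value.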